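The source may report more compounds than this note shows. Statements on the series, on what has been measured and on what is new or still open speak of the compounds shown alone.

Within the data shown here, compound 2 `CSc1ccc(F)cc1NCC1=NCCN1` gives 33.1 nM in an assay for binding affinity to Alpha-1A adrenergic receptor (Homo sapiens), read by radioligand binding (on this read-out higher numbers stand for weaker inhibition and lower numbers for stronger inhibition), the higher of the two numbers measured so far, though the gap to compound 1 `CSc1ccc(C)cc1NCC1=NCCN1`, which gives 20.9 nM, lies within the scatter. Compound 3 `COc1ccc(SC)c(NCC2=NCCN2)c1` differs from compound 2 by methoxy in place of fluoro on an aromatic carbon. Among the measured compounds shown here, the only measured step at the same carbon, a 1.6-fold higher number from compound 1 to compound 2 (0.20 log units; within the scatter), stayed within the scatter, so the series offers little guidance on this exchange. For compound 3 a step of a 1.1-fold lower number from compound 2 to compound 3 (0.04 log units; within the scatter) is therefore expected, not beyond the scatter in either direction. Compound 3 is estimated at 30 nM, with a range of 10 nM to 90 nM.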

Compound 3, inhibition constant: 174 nM
Estimate against measurement, compound 3: 5.8-fold (0.76 log units) below, and the stated range ends below it.
By their numbers in this assay, from the lowest: compounds 1 and 2 (each within the scatter of the next); then compound 3.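

The carbon para to the methylsulfanyl group does respond to its substituent: in this assay methoxy in place of fluoro gives a 5.3-fold higher number from compound 2 to compound 3 (0.72 log units; beyond the scatter) and methoxy in place of methyl gives an 8.3-fold higher number from compound 1 to compound 3 (0.92 log units; beyond the scatter), whereas fluoro and methyl could not be separated. Of the three groups at this carbon, only methoxy shifts the number, and the shift is toward weaker inhibition. No measurement available here accounts for this shift.

From the compounds shown here alone, whether the shift belongs to methoxy alone or extends to hydroxyl or ethoxy stays open. Also open, going by these compounds, is whether chloro would stay with fluoro and methyl.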